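Trifluoroethoxy in place of the azetidine on the shared core

The compounds below may be only part of what the source reports. "The series", "measured", "known", "first", "only" and "open" are said of these compounds alone.

Of the compounds shown here, three have been measured in a functional assay on cells for antagonist activity at Free fatty acid receptor 1 (Homo sapiens), read by TR-FRET and inositol phosphate accumulation, with a stated time of 2 h; on this read-out higher numbers stand for weaker inhibition and lower numbers for stronger inhibition. Compound 1 `Cc1cc(COc2ccccc2S(C)(=O)=O)nc(-c2ccccn2)n1` reaches only the limit of the assay, > 39800 nM, and so gives no number; (the limit of > 39800 nM in this assay, at which 1 of the 3 values shown sits). Compound 2 `COc1cc(COc2cccc(F)c2)nc(-c2ccccn2)n1` gives 1260 nM. Compound 3 `CC1(C)CN(c2cc(COc3ccc(F)c(F)c3F)nc(-c3ccccn3)n2)C1` gives 25.1 nM, the lowest of the two numbers, with compound 2 standing beyond the scatter from it. Compound 2 and compound 3 differ in more than one place, so no single step between them is shown.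

The next compound, compound 4 `Fc1ccc(OCc2cc(OCC(F)(F)F)nc(-c3ccccn3)n2)c(F)c1F`, differs from compound 3 in one place: 2,2,2-trifluoroethoxy in place of 3,3-dimethylazetidin-1-yl on an aromatic carbon. Among the compounds with values here, no measured pair shows this change, so its effect can only be estimated. Within the data shown here, compound 4 is expected to give a higher number than compound 3 in this assay, by a step of a 6.4-fold higher number from compound 3 to compound 4 (0.80 log units; beyond the scatter) that lies beyond the scatter, since the only compounds with an alkoxy group at that place, compound 1 and compound 2, give weaker inhibition than compound 3. For compound 4 the estimate is 160 nM, within a range from 40 nM to 630 nM.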

Compound 4, half-maximal inhibitory concentration: 7.94 nM
Compound 4: the middle estimate sits 20-fold (1.30 log units) above what was measured; the whole stated range lies above it.
By their numbers in this assay, from the lowest: compound 4; then compound 3; then compound 2. At a limit, above all of these: compound 1.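

The swap shows that the four-membered ring at this place, next to the ring nitrogen, is not needed for strong inhibition: in this assay, going from 3,3-dimethylazetidin-1-yl to the ringless 2,2,2-trifluoroethoxy gives a 3.2-fold lower number from compound 3 to compound 4 (0.50 log units; beyond the scatter). The two groups match in their counts of heavy atoms, hydrogen-bond donors and hydrogen-bond acceptors, so this single pair shows that the reading at this position can shift while those counts stay the same. Nothing measured here gives a reason for the step. The compounds shown leave open how ethoxy without its fluorine atoms, a longer fluorinated chain or a primary amine would read at this place on the shared core. On these data alone, the part played by the three fluorine atoms therefore remains unknown.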